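The source may hold more compounds than are shown below. What is called first, only, known or untested is meant among the compounds shown, and "the series" means these compounds.

The measured compounds:
compound 1 `Cc1cc(OC(=O)c2ccc(CC(CO[N+](=O)[O-])O[N+](=O)[O-])cc2)n(-c2ccccc2)n1`, 4.88
compound 2 `Cc1cc(OC(=O)OCCCCCCO[N+](=O)[O-])n(-c2ccccc2)n1`, 4.39
compound 3 `Cc1cc(OC(=O)OCCCCC(CO[N+](=O)[O-])O[N+](=O)[O-])n(-c2ccccc2)n1`, 4.63

All three were characterised in a physicochemical assay for lipophilicity, read by HPLC, measured as octanol-water partition, at pH 7; on this read-out higher numbers stand for higher lipophilicity and lower numbers for lower lipophilicity. Compound 1 stands highest of the three, with compound 3 closest to it and compound 2 furthest away; the gap from compound 1 to compound 2 lies beyond the scatter, the gap to compound 3 within it. The difference between the cores of compound 1 and compound 3 is not broken down here.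

Compound 3 and compound 2 differ in one place: hydrogen in place of nitrooxy on a saturated chain carbon bound to two saturated chain carbons. In this assay that change gave a number 0.24 log units lower from compound 3 to compound 2 (within the scatter).

Compound 4 `Cc1cc(OC(=O)c2ccc(CCCO[N+](=O)[O-])cc2)n(-c2ccccc2)n1` has not yet been measured. It is related to compound 1 by the same change, (hydrogen in place of nitrooxy on a saturated chain carbon bound to two saturated chain carbons), made at a place described in the same words as for the pair of compound 3 and compound 2.

Among the compounds with values here, for compound 4 the estimated step is a number 0.24 log units lower from compound 1 to compound 4 (within the scatter), and this expectation rests on the step seen earlier, because a number 0.24 log units lower from compound 3 to compound 2 (within the scatter) is the only measured example of this change. Since that earlier step sat within the scatter, a small change is expected here too, and the estimate for compound 4 is 4.64, expected to fall between 4.35 and 4.95.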

Compound 4, partition coefficient: 4.76
For compound 4 the middle estimate is 0.12 log units below the measured one; low and high end bracket the measured number.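

In this assay, hydrogen in place of nitrooxy on a saturated chain carbon bound to two saturated chain carbons gave a number 0.12 log units lower from compound 1 to compound 4 (within the scatter) on one core and a number 0.24 log units lower from compound 3 to compound 2 (within the scatter) on the other. The same change, carried from the core of compound 3 to the core of compound 1, therefore produced no step beyond the scatter on either core, and in that limited sense the earlier pair was a fair guide to the new one. This does not show that the change has no effect or that its size is the same on both cores, since steps this small cannot be told apart from the scatter, two pairs set no rule for the whole series, and nothing given here explains either step.

The compounds shown leave open whether the change would stay this small on a longer chain, or on a core other than these two. They also leave open what would be seen if an amine or a carboxylic acid, rather than hydrogen, took the place of nitrooxy on that same saturated chain carbon.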